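A Fluorine-to-Chlorine Swap on a Prostaglandin D2 Antagonist

The source may hold more compounds than are shown below. What is called first, only, known or untested is meant among the compounds shown, and "the series" means these compounds.

Compound 1, `O=C(O)Cc1sc(C(c2ccccc2)c2ccc(Cl)cc2)nc1-c1ccc(Cl)cc1`: 75 nM
Compound 2, `O=C(O)Cc1sc(C(c2ccccc2)c2ccc(F)cc2)nc1-c1ccc(Cl)cc1`: 36 nM
Compound 3, `O=C(O)Cc1sc(C(c2ccc(F)cc2)c2ccc(F)cc2)nc1-c1ccnc(F)c1`: 4.7 nM

All three were tested in an in vitro functional assay on HEK285-7 cells for antagonist activity at prostaglandin D2 receptor 2 (Homo sapiens), read by BRET and beta-arrestin recruitment; on this read-out lower numbers stand for stronger inhibition and higher numbers for weaker inhibition. Compound 2 and compound 1 differ in one place, (chloro in place of fluoro on an aromatic carbon), and this change gave a 2.1-fold higher number from compound 2 to compound 1 (0.32 log units; beyond the scatter). Compound 3 gives the lowest number of the three; how its core differs from that of compound 2 is not broken down here. Compound 4, `O=C(O)Cc1sc(C(c2ccc(F)cc2)c2ccc(F)cc2)nc1-c1ccnc(Cl)c1`, is not yet measured. It differs from compound 3 by chloro in place of fluoro on an aromatic carbon. This is the same kind of change as from compound 2 to compound 1, but the place differs: in compound 1 the chloro sits on a six-membered aromatic ring of carbon only, para to a large group, whereas in compound 4 it sits on a six-membered aromatic ring with 1 nitrogen, next to the ring nitrogen, meta to a large group. Because the earlier swap gave a 2.1-fold higher number from compound 2 to compound 1 (0.32 log units; beyond the scatter), a step of similar size is expected for compound 4 (a 1.9-fold higher number from compound 3 to compound 4 (0.28 log units; within the scatter)). Compound 4 is therefore estimated at 9 nM, most likely between 3.5 nM and 22 nM.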

Compound 4, half-maximal inhibitory concentration: 39 nM
The estimate for compound 4 lay 4.3-fold (0.64 log units) below the measured number; measured number above the stated range.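

On the pyridine-bearing core, going from 2-fluoropyridin-4-yl to 2-chloropyridin-4-yl gave an 8.3-fold higher number from compound 3 to compound 4 (0.92 log units; beyond the scatter). Set beside the earlier swap, the direction carries over from one core to the other, but the size does not: the same change on two cores in this assay, a 2.1-fold higher number (0.32 log units; beyond the scatter) from compound 2 to compound 1 and an 8.3-fold higher number (0.92 log units; beyond the scatter) from compound 3 to compound 4, 4.0-fold (0.60 log units) apart, beyond the scatter of two such steps. Two pairs cannot show whether the larger step comes from the ring nitrogen, from the place of the halogen on the ring, or from other differences between the two cores, so the size of this swap on a further core cannot be assumed.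

The compounds shown leave open how a bromo, a methyl, a methoxy or a nitrile would compare with fluoro at this place. They also leave open how a plain hydrogen there would compare.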